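The compounds below may be only part of what the source reports. "The series", "measured", "known", "first", "only" and "open" are said of these compounds alone.

Compound 1 `CC1=C(/C=C/C(=O)/C=C/c2cccc(C(F)(F)F)c2)C(C)(C)CCC1` gives 2800 nM in a functional assay on LNCaP cells (Homo sapiens) for cytotoxicity, read by MTT assay, with a stated time of 72 h; on this read-out higher numbers stand for weaker inhibition and lower numbers for stronger inhibition. Compound 2 `CC1=C(/C=C/C(=O)/C=C/c2ccc(C(F)(F)F)cc2)C(C)(C)CCC1` gives 9100 nM. Compound 3 `CC1=C(/C=C/C(=O)/C=C/c2cc(C(F)(F)F)cc(C(F)(F)F)c2)C(C)(C)CCC1` gives 8700 nM.

Among these three, compound 1 stands lowest; its nearest neighbour is reached by a 3.1-fold higher number from compound 1 to compound 3 (0.49 log units; beyond the scatter), and compound 2 lies further off with a higher number than compound 1. Compound 4 `CC1=C(/C=C/C(=O)/C=C/c2cccc(C)c2)C(C)(C)CCC1` differs from compound 1 by methyl in place of trifluoromethyl on an aromatic carbon. Going by the values given here, no measured step exchanges trifluoromethyl for methyl. Among the compounds with values here, the one step at hand, from compound 1 to compound 3, adds a second trifluoromethyl and is modest in size; compounds 1 and 2 differ only in where their single trifluoromethyl sits, which says nothing about a methyl. For compound 4 the change in this assay is therefore expected to be small, a 1.3-fold higher number from compound 1 to compound 4 (0.10 log units; within the scatter), with no firm direction. Compound 4 is estimated at 3500 nM, with a range from 1200 nM to 10000 nM.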

Compound 4, half-maximal inhibitory concentration: 17800 nM
Compound 4: middle estimate off by 5.1-fold (0.71 log units), on the low side, outside the stated range (above it).
By their numbers in this assay, from the lowest: compound 1; then compounds 3, 2 and 4 (each within the scatter of the next, the first and the last beyond it).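

In this assay, methyl in place of trifluoromethyl on this aromatic carbon is not a neutral exchange: the step gives a 6.4-fold higher number from compound 1 to compound 4 (0.80 log units; beyond the scatter), which means weaker inhibition. The earlier compounds shown here varied only the number and place of trifluoromethyl groups, whereas this step shows that the identity of the group on this carbon matters, and that methyl does not stand in for trifluoromethyl here. Nothing at hand accounts for this difference. Still open, from the compounds shown here alone, is how a nitrile, a chlorine or an amine on this same aromatic carbon would compare with trifluoromethyl and methyl. Also open, going by these compounds, is whether methyl would give a similar step at the other ring positions occupied in compound 2 and compound 3.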